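A few compounds are considered here, and "the series" means these few. Any claim that something is new, unique, unknown or untested is made for them only; others in the source may bear on it.

Of the compounds shown here, three have so far been tested in a functional assay on T47D cells (Homo sapiens) for cytotoxicity, read by CCK-8 assay (on this read-out lower numbers stand for stronger inhibition and higher numbers for weaker inhibition), and the fourth awaits its turn. Compound 1 `Oc1ccc(-c2cc(-c3cccs3)cc(-c3ccccc3O)n2)cc1` reaches only the limit of the assay in this assay, > 50000 nM. Compound 2 `Oc1ccc(-c2cc(-c3cccs3)cc(-c3ccc(O)cc3)n2)cc1` gives 11700 nM in this assay, a number rather than a limit. Compound 3 `Oc1ccc(-c2cc(-c3ccco3)cc(-c3ccccc3O)n2)cc1` again returns only a limit in this assay, > 50000 nM. Compound 3 therefore stands on no number of its own: of the values shown, two sit at the same limit, as noted by the limit of > 50000 nM in this assay, at which 2 of the 3 values shown sit, and only compound 2 gives a readable figure.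

Compound 4 `Oc1ccc(-c2cc(-c3ccco3)cc(-c3ccc(O)cc3)n2)cc1` is reached from compound 3 by one change: 4-hydroxyphenyl in place of 2-hydroxyphenyl on an aromatic carbon. The same exchange has been seen once already, in the move an at least 4.2-fold lower number from compound 1 to compound 2 (0.63 log units; beyond the scatter), which took the number from the limit down to a readable value. The other measured move, a step that the two limits leave unreadable from compound 1 to compound 3, cannot be sized, since both ends are limits, so it gives no guidance on how compound 4 might differ from compound 2. Among the compounds with values here, on the strength of the one readable precedent, compound 4 is expected to leave the limit and give 15000 nM, with a range from 5000 nM to 50000 nM. This estimate amounts to an expected step of an at least 3.3-fold lower number from compound 3 to compound 4 (0.52 log units; beyond the scatter).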

Compound 4, half-maximal inhibitory concentration: 21100 nM
Beside the measured number, compound 4's estimate is 1.4-fold (0.15 log units) below it; the range from low to high includes it.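

In this assay, exchanging 2-hydroxyphenyl for 4-hydroxyphenyl on the carbon next to the ring nitrogen again produces a readable number (an at least 2.3-fold lower number from compound 3 to compound 4 (0.37 log units; beyond the scatter)), so this gain now appears with furan-2-yl as well as with thiophen-2-yl. Within the data shown here, with 4-hydroxyphenyl at this position, the exchange of thiophen-2-yl for furan-2-yl can also be sized for the first time, and it stays within the scatter (a 1.8-fold higher number from compound 2 to compound 4 (0.26 log units; within the scatter)), so these two compounds cannot be ranked. The same change is therefore seen on both cores, although its size on each is only a lower bound: the same change on two cores in this assay, an at least 4.2-fold lower number (0.63 log units; beyond the scatter) from compound 1 to compound 2 and an at least 2.3-fold lower number (0.37 log units; beyond the scatter) from compound 3 to compound 4; the limit leaves it open whether they differ.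

Going by these compounds, the step between compound 1 and compound 3 cannot be read, so how these two compare and how large the hydroxyphenyl exchange truly is on either core remain open: the limit of > 50000 nM in this assay, at which 2 of the 4 values shown sit. On these data alone, it is also open whether a 4-aminophenyl or 4-carboxyphenyl group on the same carbon would give a lower number than the 4-hydroxyphenyl group does in compound 2 and compound 4.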